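Working notes: from compound 3 to compound 4

This account rests on a few compounds, and the source may have more. Where it says the series, first, only, none or still open, it means among the compounds named here.

For the measured compounds named here, in an ADME assay on the whole organism with Oryza sativa as the target, tested at 10 uM (on this read-out lower numbers stand for a stronger effect and higher numbers for a weaker effect at the one concentration tested), compound 3 `CCCCCc1ccc(NC(=O)N[C@H](C)c2ccccc2)cc1` gives 97%, the highest of the three numbers so far; compound 1 `Cc1ccc(NC(=O)N[C@H](C)c2ccccc2)cc1` gives 64% and compound 2 `CC(C)c1ccc(NC(=O)N[C@H](C)c2ccccc2)cc1` gives 49%. The steps of a number 33 percentage points higher from compound 1 to compound 3 (beyond the scatter) and a number 48 percentage points higher from compound 2 to compound 3 (beyond the scatter) both run upward toward the pentyl compound, whereas a number 15 percentage points lower from compound 1 to compound 2 (beyond the scatter) is a modest drop. Compound 4 `C[C@@H](NC(=O)Nc1ccc(C(F)(F)F)cc1)c1ccccc1` carries the change (trifluoromethyl in place of pentyl on an aromatic carbon); the entering group counts fewer heavy atoms than the pentyl it replaces, as do the methyl of compound 1 and the isopropyl of compound 2. The two large upward steps into compound 3 bear most on this, so a large step back downward in this assay is expected, a number 40 percentage points lower from compound 3 to compound 4 (beyond the scatter). For compound 4 the estimate in this assay is 57%, with a range from 38% to 80%.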

Compound 4, a percentage reported as activity, at one concentration (the size of the read-out at that concentration, not a potency): 82%
Estimate against measurement, compound 4: 25 percentage points below; the whole stated range lies below it.
By their numbers in this assay, from the lowest: compound 2; then compound 1; then compound 4; then compound 3.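

In this assay the change from pentyl to trifluoromethyl gives a number 15 percentage points lower from compound 3 to compound 4 (beyond the scatter) and so only a modest return, while the other comparisons give a number 33 percentage points higher from compound 2 to compound 4 (beyond the scatter) and a number 18 percentage points higher from compound 1 to compound 4 (beyond the scatter) at this position on the aromatic ring. A group with fewer heavy atoms than pentyl therefore does not by itself bring the number down to the level of the methyl or isopropyl compounds. Nothing at hand accounts for this difference.

Open, going by these compounds, is where a chlorine, a methoxy group or a nitrile would fall here, and whether a chain longer than pentyl would follow compound 3.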